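The source may report more compounds than this note shows. Statements on the series, on what has been measured and on what is new or still open speak of the compounds shown alone.

Compound 1 (`O=C(CN(C(=O)c1ccc(-c2ccccn2)cc1)C1CCOCC1)Nc1cc(F)cc(F)c1`), compound 2 (`O=C(CN(CC1CCC1)C(=O)c1ccc(-c2ccccn2)cc1)Nc1cc(F)cc(F)c1`) and compound 3 (`COCC(C)N(CC(=O)Nc1cc(F)cc(F)c1)C(=O)c1ccc(-c2ccccn2)cc1`) share a core and differ in the group on the amide-type nitrogen. In an in vitro ADME assay on microsomes (Homo sapiens) for metabolic stability (a lower number here means slower removal, a higher number faster removal of the compound), compound 1 gives < 0.5 mL.min-1.g-1, which is a limit of the assay and not a number. Compound 2 gives 2 mL.min-1.g-1, and compound 3 gives 5.8 mL.min-1.g-1, the highest of the numbers measured.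

Compound 4 (`CCC(COC)N(CC(=O)Nc1cc(F)cc(F)c1)C(=O)c1ccc(-c2ccccn2)cc1`) differs from compound 3 by one change, methyl in place of hydrogen on a saturated chain carbon, two bonds along the chain from an amide-type nitrogen, which turns 1-(methoxymethyl)ethyl into 1-(methoxymethyl)propyl.

For the measured compounds named here, no measured step adds a methyl alone. The closest evidence is the whole-group swaps at that nitrogen: an at least 4.0-fold higher number from compound 1 to compound 2 (0.60 log units; beyond the scatter), an at least 11-fold higher number from compound 1 to compound 3 (1.06 log units; beyond the scatter) and a 2.9-fold higher number from compound 2 to compound 3 (0.46 log units; beyond the scatter). The first two of these start from a limit. A single methyl is a smaller change than those swaps, so a small upward move is expected in this assay, possibly not beyond the scatter. The expected move is a 1.4-fold higher number from compound 3 to compound 4 (0.14 log units; within the scatter). For compound 4 the estimate is 8 mL.min-1.g-1, with an expected range of 3.5 mL.min-1.g-1 to 18 mL.min-1.g-1.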

Compound 4, intrinsic clearance in microsomes: 9.6 mL.min-1.g-1
For compound 4 the middle estimate is 1.2-fold (0.08 log units) below the measured one; low and high end bracket the measured number.
By their numbers in this assay, from the lowest: compound 2; then compounds 3 and 4 (each within the scatter of the next). At a limit, below all of these: compound 1.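

In this assay the added methyl gives a 1.7-fold higher number from compound 3 to compound 4 (0.22 log units; within the scatter) and so, at this carbon, 1-(methoxymethyl)ethyl and 1-(methoxymethyl)propyl cannot be told apart. The swap from cyclobutylmethyl to 1-(methoxymethyl)propyl gives a 4.8-fold higher number from compound 2 to compound 4 (0.68 log units; beyond the scatter) and so remains a step that can be read, as the swap to 1-(methoxymethyl)ethyl was. The swap from oxan-4-yl gives an at least 19-fold higher number from compound 1 to compound 4 (1.28 log units; beyond the scatter) and this step starts from compound 1, whose value is a limit and not a number: the limit of < 0.5 mL.min-1.g-1 in this assay, at which 1 of the 4 values shown sits.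

The compounds shown leave open whether a longer chain at this carbon, such as propyl in place of the ethyl of compound 4, would move the number beyond the scatter. They also leave open what an amine in place of the methoxy group would do at this nitrogen substituent.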